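From chloro to trifluoromethyl on an aromatic carbon

The compounds below may be only part of what the source reports. "The series", "measured", "known", "first", "only" and "open" are said of these compounds alone.

- Compound 1 `Cc1ccc(-c2nn(-c3ccccc3)cc2-c2nc3ccccc3n2S(=O)(=O)c2ccccc2)cc1` gives 830 nM here
- Compound 2 `Cc1ccc(-c2nn(-c3ccccc3)cc2-c2nc3ccccc3n2S(=O)(=O)c2ccc(F)cc2)cc1` gives 5270 nM here
- Compound 3 `Cc1ccc(-c2nn(-c3ccccc3)cc2-c2nc3ccccc3n2S(=O)(=O)c2ccc(Cl)cc2)cc1` gives 5930 nM here

All three values come from a functional assay on MCF7 cells (Homo sapiens) for antiproliferative activity, read by MTT assay, with a stated time of 24 h (on this read-out higher numbers stand for weaker inhibition and lower numbers for stronger inhibition), where a lower number means stronger inhibition of cell growth. Compound 3 shares the high end of these numbers with compound 2, and the gap between them is within the scatter. Compound 1 stands clearly apart, with the lowest number.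

Compound 4 `Cc1ccc(-c2nn(-c3ccccc3)cc2-c2nc3ccccc3n2S(=O)(=O)c2ccc(C(F)(F)F)cc2)cc1` has not been measured yet. It differs from compound 3 in one place, with trifluoromethyl in place of chloro on an aromatic carbon, para to a large group.

Two kinds of step bear on this change. Replacing hydrogen with a substituent gave modest rises, seen in a 6.3-fold higher number from compound 1 to compound 2 (0.80 log units; beyond the scatter) and a 7.1-fold higher number from compound 1 to compound 3 (0.85 log units; beyond the scatter), both beyond the scatter. Replacing one substituent with another is the closer parallel, and a 1.1-fold higher number from compound 2 to compound 3 (0.05 log units; within the scatter) stayed within the scatter. In this assay, no step beyond the scatter is therefore expected, in either direction. From the compounds shown here alone, this rests on a single swap, and trifluoromethyl itself is untested on this core, so the range is kept wide. The expected step is a 1.1-fold lower number from compound 3 to compound 4 (0.03 log units; within the scatter), a small one. The estimate for compound 4 is 5500 nM (range 2200 nM to 14000 nM).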

Compound 4, half-maximal inhibitory concentration: 2340 nM
Beside the measured number, compound 4's estimate is 2.4-fold (0.37 log units) above it; the range from low to high includes it.
By their numbers in this assay, from the lowest: compound 1; then compound 4; then compounds 2 and 3 (each within the scatter of the next).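

In this assay, within the data shown here, the earlier compounds showed only that fluoro and chloro at this position could not be told apart, but trifluoromethyl separates from both, with a 2.5-fold lower number from compound 3 to compound 4 (0.40 log units; beyond the scatter) and a 2.3-fold lower number from compound 2 to compound 4 (0.35 log units; beyond the scatter). So the identity of the group placed here matters, and not just whether a group is present. Hydrogen still keeps the lowest number of the four, with a 2.8-fold higher number from compound 1 to compound 4 (0.45 log units; beyond the scatter), so this replacement recovers only part of what the halogens lost, and no measurement shown explains why trifluoromethyl differs from fluoro and chloro.

Among these compounds, with only three groups compared against hydrogen, it remains open whether another group at this position, such as methoxy, an amine or a carboxylic acid, would bring the number closer to that of compound 1 or even below it. From the compounds shown here alone, it also remains open whether the same order of hydrogen, trifluoromethyl and the two halogens would hold at another position on this ring or on another cell line.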